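A few compounds are considered here, and "the series" means these few. Any claim that something is new, unique, unknown or untested is made for them only; others in the source may bear on it.

Values in a functional assay on A549 cells (Homo sapiens) for cytotoxicity, read by MTT assay, with a stated time of 48 h; on this read-out lower numbers stand for stronger inhibition and higher numbers for weaker inhibition:
- compound 1 `COc1cc([C@@H]2C[C@]2(CO)C(=O)NCc2ccc(C)cc2)cc(OC)c1OC`: 10500 nM
- compound 2 `COc1cc([C@@H]2C[C@@]2(CO)C(=O)NCc2ccc(C)cc2)cc(OC)c1OC`: 46300 nM
- compound 3 `COc1cc([C@H]2C[C@@]2(CO)C(=O)Nc2ccccc2Cl)cc(OC)c1OC`: > 100000 nM

The entry for compound 3, > 100000 nM, is a limit and not a number. Compound 4 `COc1cc([C@H]2C[C@@]2(CO)C(=O)NCc2ccc(C)cc2)cc(OC)c1OC` differs from it by 4-methylbenzyl in place of 2-chlorophenyl on an amide-type nitrogen. Within the data shown here, no measured step covers this exchange directly. Among the measured compounds shown here, the one measured step, a 4.4-fold higher number from compound 1 to compound 2 (0.64 log units; beyond the scatter), is modest and beyond the scatter, and it concerns (the fact that compounds 1 and 2 differ only in the configuration as drawn). Compound 1 and compound 2 both carry 4-methylbenzyl and both give numbers, so a step to a lower number is expected in this assay. The expected size is an at least 3.3-fold lower number from compound 3 to compound 4 (0.52 log units; beyond the scatter). For compound 4 the estimated value is 30000 nM. The expected range for compound 4 runs from 9000 nM to 100000 nM.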

Compound 4, half-maximal inhibitory concentration: 63800 nM
Beside the measured number, compound 4's estimate is 2.1-fold (0.33 log units) below it, and the stated range covers the measured number.
By their numbers in this assay, from the lowest: compound 1; then compounds 2 and 4 (each within the scatter of the next). At a limit, above all of these: compound 3.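

The step on the amide-type nitrogen rests on the limit of compound 3 and gives only a floor (an at least 1.5-fold lower number from compound 3 to compound 4 (0.19 log units; that floor lies within the scatter)) in this assay. Among the 4-methylbenzyl compounds, configuration does not act evenly: one inverted stereocentre separates two compounds by no more than the scatter (a 1.4-fold higher number from compound 2 to compound 4 (0.14 log units; within the scatter)). The mirror-image pair shows the widest gap in the set (a 6.1-fold higher number from compound 1 to compound 4 (0.78 log units; beyond the scatter)), leaving compound 1 apart from both other stereoisomers.

Still open, from the compounds shown here alone, is how a plain benzyl group or a longer chain on the amide-type nitrogen would read. Also open, going by these compounds, is whether 2-chlorophenyl gives a number in the configuration of compound 1.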